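Thioamide series: bromo to trifluoromethyl step, cytotoxicity notes

The source may report more compounds than this note shows. Statements on the series, on what has been measured and on what is new or still open speak of the compounds shown alone.

Measured compounds:
- compound 1, `COc1cc(Cl)ccc1C(=O)Nc1cc(Br)ccc1O`, 5630 nM
- compound 2, `COc1cc(Cl)ccc1C(=O)Nc1cc(C(F)(F)F)ccc1O`, 25400 nM
- compound 3, `COc1ccc(Cl)cc1C(=S)Nc1cc(Br)ccc1O`, 8740 nM

All three numbers come from a functional assay on HepG2 cells (Homo sapiens) for cytotoxicity, with a stated time of 24 h; on this read-out lower numbers stand for stronger inhibition and higher numbers for weaker inhibition. Compound 1 and compound 2 share one core and differ by trifluoromethyl in place of bromo on an aromatic carbon; this change gave a 4.5-fold higher number from compound 1 to compound 2 (0.65 log units; beyond the scatter). Compound 3 carries a different core; the difference between the core of compound 1 and the core of compound 3 is not broken down here. In this assay compound 3 gives 8740 nM, which sits within the scatter of the number for compound 1, so no order between those two is claimed; against compound 2 the gap is beyond the scatter.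

Compound 4, `COc1ccc(Cl)cc1C(=S)Nc1cc(C(F)(F)F)ccc1O`, is not yet measured. It differs from compound 3 by trifluoromethyl in place of bromo on an aromatic carbon, the same change, at the same place, as that from compound 1 to compound 2. The expectation for compound 4 in this assay rests on one earlier instance of this change, a 4.5-fold higher number from compound 1 to compound 2 (0.65 log units; beyond the scatter), applied to the number for compound 3, 8740 nM. The cores differ in a way that is not broken down, so the transfer is uncertain. The expected step for compound 4 is a 4.0-fold higher number from compound 3 to compound 4 (0.60 log units; beyond the scatter), set close to the earlier one but with a wide range. The estimated value for compound 4 is 35000 nM, with an expected range from 15000 nM to 80000 nM.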

Compound 4, half-maximal inhibitory concentration: 5860 nM
The estimate for compound 4 lay 6.0-fold (0.78 log units) above the measured number, and the stated range ends above it.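

In this assay, trifluoromethyl in place of bromo gave a 1.5-fold lower number from compound 3 to compound 4 (0.17 log units; within the scatter), so on the core of compound 3 this change brings no step beyond the scatter, and no order between the two compounds is claimed. Set beside the earlier instance, the same change at the same place does not carry over as a fixed step from one core to the other: the same change on two cores in this assay, a 4.5-fold higher number (0.65 log units; beyond the scatter) from compound 1 to compound 2 and a 1.5-fold lower number (0.17 log units; within the scatter) from compound 3 to compound 4, 6.7-fold (0.83 log units) apart, beyond the scatter of two such steps. This shows that a step seen on the core of compound 1 cannot simply be applied to the core of compound 3, but it rests on two instances only, and because the difference between the cores is not broken down, it does not show which part of the core goes with the different outcome or how the change would behave on any further core.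

The compounds shown carry only bromo and trifluoromethyl at this place, so it remains open whether a nitrile, an amine or a carboxylic acid there would follow the step seen on the core of compound 1 or the one seen on the core of compound 3. With a single cell read-out shown, it also remains open whether the gap between the two steps would hold in any other assay.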